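Swapping Methyl for Fluoro on a Shared Core

The compounds below may be only part of what the source reports. "The series", "measured", "known", "first", "only" and "open" are said of these compounds alone.

Three compounds built on a shared core were tested in a functional assay on OVCAR-3 cells (Homo sapiens) for antiproliferative activity, read by MTT assay, with a stated time of 24 h; on this read-out higher numbers stand for weaker inhibition and lower numbers for stronger inhibition. Compound 1 `O=c1[nH]cc(S(=O)(=O)Nc2ccccc2-c2cn(-c3ccc(F)cc3)nn2)c(=O)[nH]1` gives only a limit of > 20000 nM in this assay. Compound 2 `O=c1[nH]cc(S(=O)(=O)Nc2cccc(-c3cn(-c4cccc(Cl)c4)nn3)c2)c(=O)[nH]1` gives 3410 nM, and compound 3 `Cc1cccc(-n2cc(-c3ccc(NS(=O)(=O)c4c[nH]c(=O)[nH]c4=O)cc3)nn2)c1` gives 7490 nM, the higher of these two numbers, with the gap to compound 2 lying beyond the usual scatter. Compound 4 `O=c1[nH]cc(S(=O)(=O)Nc2ccc(-c3cn(-c4cccc(F)c4)nn3)cc2)c(=O)[nH]1` differs from compound 3 in one place: fluoro in place of methyl on an aromatic carbon. Going by the values given here, no measured pair shows this change; a small step at most is expected in this assay. The step of a 1.1-fold lower number from compound 3 to compound 4 (0.03 log units; within the scatter) is expected to stay within the scatter. Compound 4 is estimated at 7000 nM, within 2500 nM to 20000 nM.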

Compound 4, half-maximal inhibitory concentration: > 20000 nM
Compound 4: a limit, no number; the forecaster's own chance of this, stated with the estimate: 10%; middle value at least 2.8-fold (0.45 log units) away from the limit.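

In this assay, going by these compounds alone, fluoro in place of methyl on an aromatic carbon gives an at least 2.6-fold higher number from compound 3 to compound 4 (0.42 log units; beyond the scatter), so even this one-atom change at this position can weaken inhibition, something the earlier compounds could not show because no two of them differed in one place. Compound 4 gives only a limit, so the full size of the step stays unknown: the limit of > 20000 nM in this assay, at which 2 of the 4 values shown sit.

On these data alone, whether the weakening comes from the fluoro entering or the methyl leaving stays open. So does how an ethyl group, a methoxy group or an amine would behave in this same place.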